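This account rests on a few compounds, and the source may have more. Where it says the series, first, only, none or still open, it means among the compounds named here.

Compound 1, `NC(=O)[C@@H]1CC[C@H](c2ccc(OCc3ccccc3)cc2)N1`; compound 2, `NC(=O)[C@@H]1CC[C@H](c2ccc(Oc3cccc(F)c3)cc2)N1`; compound 3, `NC(=O)[C@@H]1CC[C@H](c2ccc(Oc3ccc(F)cc3)cc2)N1`, not yet measured.

In an assay on HEK293 cells for inhibition of sodium channel protein type 3 subunit alpha (Homo sapiens), read by electrophysiology, with a stated time of 3.5 min (on this read-out lower numbers stand for stronger inhibition and higher numbers for weaker inhibition), compound 1 gives only a limit, > 63000 nM. In this assay, among the measured compounds shown here, compound 2 gives 100000 nM, the only number among the values shown. The step that the limit leaves unreadable from compound 1 to compound 2 is unreadable in size, since the limit of > 63000 nM in this assay, at which 1 of the 2 values shown sits, leaves it open. Compound 3 differs from compound 2 by 4-fluorophenyl in place of 3-fluorophenyl on an oxygen on an aromatic ring. For the measured compounds named here, no measured step bears on this change, so no step beyond the scatter is expected in this assay. The expected step is no change at the digits printed from compound 2 to compound 3 (within the scatter). Compound 3 is thus estimated at 100000 nM, within 30000 nM to 300000 nM.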

Compound 3, half-maximal inhibitory concentration: > 100000 nM
Compound 3 was reported as a limit; the forecaster's own chance of this, stated with the estimate: 60%; the middle value lies on the limit itself.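

In this assay compound 3 gives only a limit, > 100000 nM. Setting 4-fluorophenyl in place of 3-fluorophenyl on an oxygen on an aromatic ring gives a number no lower from compound 2 to compound 3 (the limit leaves the size open), so this change shows no gain in inhibition that the read-out can detect. The sizes of the steps that touch a limit cannot be read: the limit of > 100000 nM in this assay, at which 1 of the 3 values shown sits.

The compounds shown leave open whether any group on that oxygen gives stronger inhibition in this assay. An amine or a carboxylic acid in place of the fluorophenyl remains an open case.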